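One Swap on Two Cores: Expecting a Cytotoxicity Value

This account rests on a few compounds, and the source may have more. Where it says the series, first, only, none or still open, it means among the compounds named here.

Measured so far in a functional assay on MCF7 cells (Homo sapiens) for cytotoxicity, read by MTT assay, with a stated time of 72 h; on this read-out higher numbers stand for weaker inhibition and lower numbers for stronger inhibition:
compound 1, `Cc1cc(=O)n(-c2ccc(Br)cc2F)nc1C(=O)Nc1ccc(Oc2ncnc3ccsc23)cc1`, gives 9360 nM
compound 2, `Cc1cc(=O)n(-c2ccccc2OC(F)(F)F)nc1C(=O)Nc1ccc(Oc2ncnc3ccsc23)cc1`, gives 23800 nM
compound 3, `Cc1cc(=O)n(-c2ccc(Br)cc2F)nc1C(=O)Nc1ccc(Oc2ncnc3sccc23)c(F)c1`, gives 13300 nM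

Compound 4, `Cc1cc(=O)n(-c2ccccc2OC(F)(F)F)nc1C(=O)Nc1ccc(Oc2ncnc3sccc23)c(F)c1`, has not yet been measured. It stands to compound 3 as compound 2 stands to compound 1: the change is 2-(trifluoromethoxy)phenyl in place of 4-bromo-2-fluorophenyl on an aromatic nitrogen. The same change, (2-(trifluoromethoxy)phenyl in place of 4-bromo-2-fluorophenyl on an aromatic nitrogen), produced a 2.5-fold higher number from compound 1 to compound 2 (0.41 log units; beyond the scatter) in this assay. The difference between the core of compound 1 and the core of compound 3 is not broken down here; the values of compound 1 and compound 3 lie within the usual scatter of each other, so nothing separates the two cores on this read-out. The step from compound 3 to compound 4 is expected to be about as large, a 2.5-fold higher number from compound 3 to compound 4 (0.39 log units; beyond the scatter), because the same change once gave a 2.5-fold higher number from compound 1 to compound 2 (0.41 log units; beyond the scatter). Compound 4 is therefore estimated at 33000 nM, with a likely range from 15000 nM to 70000 nM.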

Compound 4, half-maximal inhibitory concentration: > 40000 nM
Compound 4: a limit, no number; the forecaster's own chance of this, stated with the estimate: 15%; at least 1.2-fold (0.08 log units) between middle value and limit.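

On the core of compound 3, putting 2-(trifluoromethoxy)phenyl in place of 4-bromo-2-fluorophenyl gives, in this assay, an at least 3.0-fold higher number from compound 3 to compound 4 (0.47 log units; beyond the scatter), so the change moves the number the same way on both cores. Compound 4 reads > 40000 nM, which is a limit of the assay and not a number. The true size of this step therefore stays unknown, and the data do not show whether the change has an equal effect on the two cores: the same change on two cores in this assay, a 2.5-fold higher number (0.41 log units; beyond the scatter) from compound 1 to compound 2 and an at least 3.0-fold higher number (0.47 log units; beyond the scatter) from compound 3 to compound 4; the limit leaves it open whether they differ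

The compounds shown test this change with only one pair on each of two cores. They leave open whether a different group on the aromatic nitrogen, such as one carrying an amine or a carboxylic acid, would carry over between the cores in the same way.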